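Benzamide variant of the pyrazole series, cytotoxicity in melanoma cells

A few compounds are considered here, and "the series" means these few. Any claim that something is new, unique, unknown or untested is made for them only; others in the source may bear on it.

Two compounds have numbers in a functional assay on SK-MEL-5 cells (Homo sapiens) for inhibition, read by sulforhodamine B assay, with a stated time of 48 h; on this read-out higher numbers stand for lower toxicity in this test and lower numbers for higher toxicity in this test. Compound 1 `COc1cc(-c2nn(-c3cccc(NC(=O)c4ccc(Cl)c(C(F)(F)F)c4)c3)cc2-c2ccncc2)ccc1Cl` gives 31800 nM and compound 2 `COc1cc(-c2nn(-c3cccc(NC(=O)Nc4ccc(Cl)c(C(F)(F)F)c4)c3)cc2-c2ccncc2)ccc1Cl` gives 10400 nM. Within the data shown here, the one step measured, a 3.1-fold lower number from compound 1 to compound 2 (0.49 log units; beyond the scatter), puts compound 2 at the lowest number of the two, with compound 1 as its only neighbour.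

Compound 3 `COc1cc(-c2nn(-c3cccc(NC(=O)c4ccccc4)c3)cc2-c2ccncc2)ccc1Cl` differs from compound 2 by phenyl in place of (4-chloro-3-(trifluoromethyl)phenyl)amino on a carbonyl carbon. Among the measured compounds shown here, the step from compound 2 to compound 3 thus reverses the urea-for-amide exchange of the measured step and at the same time removes the chlorine and trifluoromethyl groups; no measured pair covers the second part. For the measured compounds named here, the measured step alone suggests that returning to the amide raises the number again, and the loss of the two substituents has no precedent here, so a moderate rise toward the value of compound 1 is expected. For compound 3 the number in this assay is estimated at 45000 nM, within 15000 nM to 120000 nM, an expected step of a 4.3-fold higher number from compound 2 to compound 3 (0.64 log units; beyond the scatter).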

Compound 3, concentration lethal to 50% of the cells: 7100 nM
Estimate against measurement, compound 3: 6.3-fold (0.80 log units) above, and the stated range ends above it.
By their numbers in this assay, from the lowest: compounds 3 and 2 (each within the scatter of the next); then compound 1.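

On the carbonyl carbon of the amide, phenyl in place of 4-chloro-3-(trifluoromethyl)phenyl gives a 4.5-fold lower number from compound 1 to compound 3 (0.65 log units; beyond the scatter) in this assay, so within this pair the chlorine and trifluoromethyl groups go with the higher number and lower toxicity in this test. Phenyl in place of (4-chloro-3-(trifluoromethyl)phenyl)amino gives a 1.5-fold lower number from compound 2 to compound 3 (0.17 log units; within the scatter) and leaves no order between these two compounds, so the plain benzamide and the substituted urea cannot be told apart in this assay. No supporting data bear on the origin of either step.

Still open, from the compounds shown here alone, is how phenylamino on the same carbonyl carbon would compare with phenyl, and whether chlorine or trifluoromethyl alone carries the step seen with the amides. Also open, going by these compounds, is how a non-aromatic group such as cyclohexyl or a short alkyl chain would read in place of phenyl.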